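Aryl swaps on a shared core: cytotoxicity notes

This account rests on a few compounds, and the source may have more. Where it says the series, first, only, none or still open, it means among the compounds named here.

Measured compounds:
compound 1 `O=C(O)c1ccc(CN2C(=O)S/C(=C\c3cccnc3)C2=O)cc1`: 75000 nM
compound 2 `Cn1cccc1/C=C1\SC(=O)N(Cc2ccc(C(=O)O)cc2)C1=O`: 80000 nM
compound 3 `O=C(O)c1ccc(CN2C(=O)S/C(=C\c3ccccc3)C2=O)cc1`: 90000 nM

All three were read in a functional assay on A549 cells (Homo sapiens) for cytotoxicity, read by MTT assay, with a stated time of 24 h (on this read-out lower numbers stand for stronger inhibition and higher numbers for weaker inhibition), where compound 1 gives 75000 nM, compound 2 gives 80000 nM and compound 3 gives 90000 nM. The three numbers sit within the scatter of one another; compound 2 lies among them, nearest to compound 1 and furthest from compound 3, with neither gap meaningful. The steps that swap the aryl group on the double-bonded chain carbon are a 1.1-fold higher number from compound 1 to compound 2 (0.03 log units; within the scatter), a 1.2-fold higher number from compound 1 to compound 3 (0.08 log units; within the scatter) and a 1.1-fold higher number from compound 2 to compound 3 (0.05 log units; within the scatter); none leaves the scatter.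

Compound 4 `COc1ccc(/C=C2\SC(=O)N(Cc3ccc(C(=O)O)cc3)C2=O)cc1` is not yet measured. It differs from compound 2 as follows: 4-methoxyphenyl in place of 1-methyl-1H-pyrrol-2-yl on a double-bonded chain carbon bound to a double-bonded ring carbon. Within the data shown here, since every aryl exchange at this place so far, including the step from compound 1 to compound 3 with its a 1.2-fold higher number from compound 1 to compound 3 (0.08 log units; within the scatter), has been flat, no shift beyond the scatter is expected here either. Compound 4 is therefore estimated at 85000 nM, within 50000 nM to 150000 nM, which amounts to an expected step of a 1.1-fold higher number from compound 2 to compound 4 (0.03 log units; within the scatter).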

Compound 4, half-maximal inhibitory concentration: 44000 nM
Compound 4: middle estimate off by 1.9-fold (0.29 log units), on the high side, outside the stated range (below it).
By their numbers in this assay, from the lowest: compounds 4, 1, 2 and 3 (each within the scatter of the next, the first and the last beyond it).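

In this assay, among these compounds, methoxy in place of hydrogen on an aromatic carbon gives a 2.0-fold lower number from compound 3 to compound 4 (0.31 log units; beyond the scatter) and is thus the first change at this position to leave the scatter, though only modestly. The position is therefore not fully flat, but compound 4 separates only from compound 3, with a 1.8-fold lower number from compound 2 to compound 4 (0.26 log units; within the scatter) and a 1.7-fold lower number from compound 1 to compound 4 (0.23 log units; within the scatter) both staying within the scatter. Nothing at hand accounts for the step from compound 3 to compound 4.

As far as these compounds go, whether the step is specific to methoxy stays open, as an amine or a hydroxy group on the same aromatic carbon would be needed to test it. Also open, from the compounds shown here alone, is whether a longer alkoxy chain there would extend the step or leave the number within the scatter of compound 4.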